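This account rests on a few compounds, and the source may have more. Where it says the series, first, only, none or still open, it means among the compounds named here.

Measured compounds: compound 1 `O=C(CSCc1nc2cc([N+](=O)[O-])ccc2[nH]1)c1ccccc1`, 16100 nM; compound 2 `NC(=O)CSCc1nc2cc([N+](=O)[O-])ccc2[nH]1`, 26900 nM.

In a functional assay on HepG2 cells (Homo sapiens) for cytotoxicity, read by MTT assay, with a stated time of 48 h (a lower number here means a stronger inhibitor, a higher number a weaker inhibitor), compound 2 gives the highest of the two numbers, with compound 1 nearest, and the step of a 1.7-fold higher number from compound 1 to compound 2 (0.22 log units; within the scatter) lies within the scatter. Compound 3 `CC1=NN(C(=O)CSCc2nc3cc([N+](=O)[O-])ccc3[nH]2)C(=O)C1` differs from compound 2 by a group of 7 heavy atoms (4 carbon, 2 nitrogen, 1 oxygen; one five-membered non-aromatic ring with 2 hetero atoms) in place of one nitrogen atom, on a carbonyl carbon. For the measured compounds named here, the only measured step touches the same carbonyl carbon and was small, so no step beyond the scatter is expected from compound 2 to compound 3, perhaps a slightly lower number as the group grows. Compound 3 is estimated at 20000 nM, within 7000 nM to 60000 nM, an expected step of a 1.3-fold lower number from compound 2 to compound 3 (0.13 log units; within the scatter).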

Compound 3, half-maximal inhibitory concentration: 7330 nM
Compound 3: the middle estimate sits 2.7-fold (0.44 log units) above what was measured, and the stated range covers the measured number.
By their numbers in this assay, from the lowest: compound 3; then compounds 1 and 2 (each within the scatter of the next).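

On the carbonyl carbon, the earlier change from phenyl to amino stayed within the scatter in this assay, so the position could have seemed indifferent to what sits there. For the compounds shown here, the five-membered ring group is the first to give steps beyond the scatter, though modest ones: a 3.7-fold lower number from compound 2 to compound 3 (0.56 log units; beyond the scatter) and a 2.2-fold lower number from compound 1 to compound 3 (0.34 log units; beyond the scatter). Nothing available bears on the reason for this shift.

On these data alone, whether a piperidine ring or a longer chain on the same carbonyl carbon would give a similar step stays open. So does whether this particular ring is needed at all.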